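Swapping the Thiadiazole for a Triazole on the Sulfur

This account rests on a few compounds, and the source may have more. Where it says the series, first, only, none or still open, it means among the compounds named here.

Three compounds sharing one core have been tested in an ADME assay on NIH3T3 cells (Mus musculus) for cytotoxicity, read by MTT assay, with a stated time of 24 h; a lower number here means a stronger inhibitor, a higher number a weaker inhibitor:

Compound 1, `Cn1cnnc1SCC(=O)N/N=c1/scc(-c2ccc(C#N)cc2)n1-c1ccccc1`, gives 153 ug/mL.
Compound 2, `Cn1cnnc1SCC(=O)N/N=c1/scc(-c2ccc(Br)cc2)n1-c1ccccc1`, gives 58.3 ug/mL.
Compound 3, `Cc1nnc(SCC(=O)N/N=c2/scc(-c3ccc(F)cc3)n2-c2ccccc2)s1`, gives 383 ug/mL.

Among these three, compound 3 has the highest number, meaning it is the weakest inhibitor of the set; compound 1 is nearest to it and compound 2 furthest, both beyond the usual scatter. Among the compounds with values here, the only step measured between two compounds differing in one place is a 2.6-fold lower number from compound 1 to compound 2 (0.42 log units; beyond the scatter), which concerns the group on the aromatic ring, not the heterocycle attached to the sulfur.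

The next compound, compound 4, `Cn1cnnc1SCC(=O)N/N=c1/scc(-c2ccc(F)cc2)n1-c1ccccc1`, differs from compound 3 in exactly that heterocycle: 4-methyl-4H-1,2,4-triazol-3-yl in place of 5-methyl-1,3,4-thiadiazol-2-yl on a sulfur. Within the data shown here, no measured step covers this change directly. What the numbers do show is that compound 1 and compound 2, both carrying the 4-methyl-4H-1,2,4-triazol-3-yl, give lower numbers than compound 3 with its 5-methyl-1,3,4-thiadiazol-2-yl, though their aromatic groups differ as well. On that basis a modestly lower number is expected for compound 4, possibly no larger than the scatter, as a 2.1-fold lower number from compound 3 to compound 4 (0.33 log units; beyond the scatter). Compound 4 is therefore estimated at 180 ug/mL, with a range from 70 ug/mL to 450 ug/mL.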

Compound 4, half-maximal inhibitory concentration: 65 ug/mL
Compound 4: middle estimate off by 2.8-fold (0.44 log units), on the high side; measured number below the stated range.
By their numbers in this assay, from the lowest: compounds 2 and 4 (each within the scatter of the next); then compound 1; then compound 3.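

In this assay, the step at this position on the sulfur can now be read directly: 4-methyl-4H-1,2,4-triazol-3-yl in place of 5-methyl-1,3,4-thiadiazol-2-yl gives a 5.9-fold lower number from compound 3 to compound 4 (0.77 log units; beyond the scatter), a change that keeps the count of heavy atoms and exchanges one sulfur for one nitrogen. Within the data shown here, with the triazole held fixed, fluoro in place of bromo gives a 1.1-fold higher number from compound 2 to compound 4 (0.05 log units; within the scatter) and fluoro in place of cyano gives a 2.4-fold lower number from compound 1 to compound 4 (0.37 log units; beyond the scatter), so among the single changes measured here the heterocycle swap on the sulfur is the largest step. Nothing measured alongside these numbers accounts for the size of that step.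

Among these compounds, the swap has been seen only with fluoro on the aromatic ring, so it remains open whether it would be of the same size with bromo or cyano there. Going by these compounds, it is also open how this number would respond to a different group on the sulfur, such as a pyridine ring or a longer chain, and whether any heterocycle with a carboxylic acid or an amine would follow the triazole or the thiadiazole.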